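The compounds below may be only part of what the source reports. "The series", "measured", "known", "first", "only" and "open" are said of these compounds alone.

Of the compounds shown here, two with a shared core have been measured in a functional assay on MDA-MB-231 cells (Homo sapiens) for inhibition, read by MTT assay and WST assay, with a stated time of 72 h, tested at 10 uM; on this read-out lower numbers stand for less inhibition of growth and higher numbers for more inhibition of growth at the one concentration tested. Compound 1 `O=C(Nc1ccc(Oc2ccc(-c3nccs3)cc2)cc1)Nc1cccc(C(F)(F)F)c1` gives 64.1% in this assay, and compound 2 `O=C(Nc1ccc(Oc2ccc(-c3nccs3)cc2)cc1)Nc1cc(Br)cc(C(F)(F)F)c1` gives 72.8%. Among the measured compounds shown here, the only measured step, a number 8.7 percentage points higher from compound 1 to compound 2 (within the scatter), lies within the scatter. Compound 2 thus stands highest of the two numbers, with compound 1 nearest and within the scatter of it.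

Compound 3 `O=C(Nc1ccc(Oc2ccc(-c3nccs3)cc2)cc1)Nc1ccc(F)c(Cl)c1` is not yet measured. It differs from compound 2 in one place: 3-chloro-4-fluorophenyl in place of 3-bromo-5-(trifluoromethyl)phenyl on an amide-type nitrogen. For the measured compounds named here, the step of a number 8.7 percentage points higher from compound 1 to compound 2 (within the scatter) is the only one that touches this ring, and it shows that swapping a halogen for hydrogen there stayed within the scatter. Compound 3 changes more of that ring at once, so a modest drop seems possible, but nothing beyond the scatter is firmly expected. The estimated step is a number 12.8 percentage points lower from compound 2 to compound 3 (beyond the scatter). Compound 3 is therefore expected to give about 60%, in a range from 40% to 78%.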

Compound 3, percent growth inhibition at one concentration: 43.9%
For compound 3 the middle estimate is 16.1 percentage points above the measured one; the measured number falls inside the stated range.
By their numbers in this assay, from the lowest: compound 3; then compounds 1 and 2 (each within the scatter of the next).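

In this assay, the ring on the amide-type nitrogen can clearly shift the result: putting 3-chloro-4-fluorophenyl in place of 3-bromo-5-(trifluoromethyl)phenyl gives a number 28.9 percentage points lower from compound 2 to compound 3 (beyond the scatter), and putting it in place of 3-(trifluoromethyl)phenyl gives a number 20.2 percentage points lower from compound 1 to compound 3 (beyond the scatter). Among the compounds shown here, until now, the only change at this ring had stayed within the scatter, whereas these two steps both go beyond it, and both remove a ring bearing trifluoromethyl. No measurement shown here explains why the number falls.

Each step changes several substituents at once, so the loss of trifluoromethyl cannot be separated from the arrival of chloro and fluoro. Going by these compounds, how a ring carrying an amine, a carboxylic acid or a methoxy group would behave at this position also remains open.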